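Aryl substituent changes on the shared core

The source may report more compounds than this note shows. Statements on the series, on what has been measured and on what is new or still open speak of the compounds shown alone.

Compound 3 `Cc1cccc(N2C(=O)[C@H]3[C@H](ON4[C@@H]3C(=O)N(C)[C@@]43C[C@H](C)CC[C@H]3C(C)C)C2=O)c1` gives 35.3% in a functional assay, read by spectrophotometry, with a stated time of 2 h, tested at 2 mg/mL (on this read-out higher numbers stand for a stronger effect at the one concentration tested and lower numbers for a weaker effect), the smallest of the three numbers in the set. Compound 1 `CC(C)[C@@H]1CC[C@@H](C)C[C@@]12N(C)C(=O)[C@@H]1[C@H]3C(=O)N(c4ccccc4)C(=O)[C@H]3ON12` gives 41% in this assay, and the gap a number 5.7 percentage points lower from compound 1 to compound 3 (within the scatter) is within the scatter. Compound 2 `CC(C)[C@@H]1CC[C@@H](C)C[C@@]12N(C)C(=O)[C@@H]1[C@H]3C(=O)N(c4ccc(Cl)cc4)C(=O)[C@H]3ON12` gives 49.4% in this assay, and the gap a number 14.1 percentage points lower from compound 2 to compound 3 (beyond the scatter) is beyond the scatter, so compound 3 is separated from compound 2 but not from compound 1.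

Compound 4 `Cc1ccc(N2C(=O)[C@H]3[C@H](ON4[C@@H]3C(=O)N(C)[C@@]43C[C@H](C)CC[C@H]3C(C)C)C2=O)c(C)c1` differs from compound 3 only at the aryl group on the amide-type nitrogen in the ring: 2,4-dimethylphenyl in place of 3-methylphenyl on an amide-type nitrogen in a ring. The measured steps that bear on this place are single aromatic substitutions: a number 5.7 percentage points lower from compound 1 to compound 3 (within the scatter) for a methyl in place of hydrogen, and a number 8.4 percentage points higher from compound 1 to compound 2 (within the scatter) for a chloro in place of hydrogen, both within the scatter. Adding a second methyl to the aryl ring is therefore expected to give no step beyond the scatter in this assay, in either direction. The expected step is a number 1.7 percentage points higher from compound 3 to compound 4 (within the scatter). For compound 4 the estimate in this assay is 37%, with a range from 26% to 50%.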

Compound 4, a percentage reported as activity, at one concentration (the size of the read-out at that concentration, not a potency): 79.4%
For compound 4 the middle estimate is 42.4 percentage points below the measured one; measured number above the stated range.
By their numbers in this assay, from the lowest: compounds 3, 1 and 2 (each within the scatter of the next, the first and the last beyond it); then compound 4.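

The aryl group on the amide-type nitrogen in a ring is more sensitive in this assay than the phenyl, 4-chlorophenyl and 3-methylphenyl groups suggested: 2,4-dimethylphenyl gives a number 44.1 percentage points higher from compound 3 to compound 4 (beyond the scatter), a number 38.4 percentage points higher from compound 1 to compound 4 (beyond the scatter) and a number 30 percentage points higher from compound 2 to compound 4 (beyond the scatter). The 3-methylphenyl and 2,4-dimethylphenyl groups differ by one carbon, and neither has hydrogen-bond donors, hydrogen-bond acceptors or a net charge, so a small change in the group can accompany a large change in the number. Nothing available explains the rise.

The compounds shown leave open whether the rise requires both methyl groups of 2,4-dimethylphenyl or follows from only one of them. They also leave open whether a methoxy group, an amine or a carboxylic acid on the aryl ring would keep the number at this level.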